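This account rests on a few compounds, and the source may have more. Where it says the series, first, only, none or still open, it means among the compounds named here.

The shared core of this small series is seen in compound 1 `COc1cc(C2=NN(C(C)=O)C(c3cccc(OC)c3OC)O2)cc(OC)c1OC`. In a functional assay on PC-3 cells (Homo sapiens) for antiproliferative activity, read by MTT assay, tested at 1 uM (on this read-out higher numbers stand for a stronger effect at the one concentration tested and lower numbers for a weaker effect), compound 1 gives 35%. Compound 2 `COc1ccc(C2OC(c3cc(OC)c(OC)c(OC)c3)=NN2C(C)=O)c(OC)c1` gives 69.5% in this assay, and compound 3 `COc1cc(C2=NN(C(C)=O)C(c3ccc(C(F)(F)F)cc3)O2)cc(OC)c1OC` gives -11%. Compound 3 thus stands lowest of the three numbers: compound 1 is its nearest neighbour and compound 2 its furthest, as the steps of a number 46 percentage points lower from compound 1 to compound 3 (beyond the scatter) and a number 80.5 percentage points lower from compound 2 to compound 3 (beyond the scatter) show. Both of those steps put 4-(trifluoromethyl)phenyl on the saturated ring carbon in place of a dimethoxyphenyl group, and both were large losses. The step of a number 34.5 percentage points higher from compound 1 to compound 2 (beyond the scatter) shows that changing only which dimethoxyphenyl sits there also moved the number a great deal.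

Compound 4 `COc1cc(C2=NN(C(C)=O)C(c3ccccc3F)O2)cc(OC)c1OC` has not yet been measured. It differs from compound 3 at the same saturated ring carbon: 2-fluorophenyl in place of 4-(trifluoromethyl)phenyl on a saturated ring carbon. For the measured compounds named here, no measured step swaps one fluorinated phenyl for another, so the expectation rests on the trifluoromethyl group, present in compound 3, which gives -11%, leaving in compound 4. Going by the values given here, the single fluorine on the entering ring has no precedent here. A modest rise is expected, a number 21 percentage points higher from compound 3 to compound 4 (beyond the scatter). Compound 4 is therefore estimated at 10%, within a range from -15% to 40%.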

Compound 4, a percentage reported as inhibition, at one concentration (the size of the read-out at that concentration, not a potency): 13.5%
The estimate for compound 4 lay 3.5 percentage points below the measured number; the measured number falls inside the stated range.
By their numbers in this assay, from the lowest: compound 3; then compound 4; then compound 1; then compound 2.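

For the compounds shown here, replacing 4-(trifluoromethyl)phenyl with 2-fluorophenyl on the saturated ring carbon gives a number 24.5 percentage points higher from compound 3 to compound 4 (beyond the scatter) in this assay, the first measured change here between two fluorinated phenyl groups, and it shows that the number can move beyond the scatter even when neither group carries a methoxy group. Both dimethoxyphenyl groups still stand above 2-fluorophenyl, with a number 21.5 percentage points lower from compound 1 to compound 4 (beyond the scatter) and a number 56 percentage points lower from compound 2 to compound 4 (beyond the scatter), so across these four compounds the two fluorinated phenyl groups give the two lowest numbers, and the 2,4-dimethoxyphenyl group keeps a far wider lead than the 2,3-dimethoxyphenyl group does. No measurement shown here explains why these groups give such different numbers.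

The step from compound 3 to compound 4 alters both the fluorinated group and its place on the phenyl ring, so the compounds shown cannot separate those two changes; 4-fluorophenyl and unsubstituted phenyl on the same carbon would help to do that. They also leave open how an amine on that phenyl ring would read, and whether a longer chain such as propanoyl could stand in for the acetyl group on the ring nitrogen.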